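The source may report more compounds than this note shows. Statements on the series, on what has been measured and on what is new or still open speak of the compounds shown alone.

Compound 1 `O=C1C(=O)N(CCCn2cc(COc3cc(=O)oc4ccccc34)nn2)c2ccc(F)cc21` was run in a functional assay on HCT-116 cells (Homo sapiens) for inhibition, read by sulforhodamine B assay, with a stated time of 48 h, tested at 50 uM (a higher number here means more inhibition of growth at the concentration tested, a lower number less inhibition of growth), and in that test compound 1 gives 75%. Two companions from the same series, compound 2 `O=C1C(=O)N(CCCCCn2cc(COc3cc(=O)oc4ccccc34)nn2)c2ccc(Br)cc21` and compound 3 `O=C1C(=O)N(CCCCn2cc(COc3cc(=O)oc4ccccc34)nn2)c2ccc(Br)cc21`, carry a bromo group in place of the fluoro group and a longer chain within the shared core. In this assay compound 2 gives 43%, and compound 3 gives 59%. Compound 1 therefore holds the highest number of the three; its gap to compound 3 and its wider gap to compound 2 both lie beyond the usual scatter. No two of the measured compounds differ in only one place, so the effect of any single change cannot be read from them.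

Compound 4 `O=C1C(=O)N(CCCn2cc(COc3cc(=O)oc4ccccc34)nn2)c2ccccc21` differs from compound 1 in one place: hydrogen in place of fluoro on an aromatic carbon. Nothing measured here shows what removing a fluoro group alone does, so the step from compound 1 to compound 4 is expected to be modest, a number 10 percentage points lower from compound 1 to compound 4 (within the scatter), perhaps a slight loss or none beyond the scatter. Compound 4 is expected to give about 65%, estimated to fall between 45% and 80%.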

Compound 4, percent growth inhibition at one concentration: 79%
Estimate against measurement, compound 4: 14 percentage points below; measured number inside the range.
By their numbers in this assay, from the lowest: compound 2; then compound 3; then compounds 1 and 4 (each within the scatter of the next).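

Within the data shown here, putting hydrogen in place of fluoro on this aromatic carbon gives, in this assay, a number 4 percentage points higher from compound 1 to compound 4 (within the scatter), and this is the first comparison in the set that isolates a single change. With the chain of compound 1 held fixed, the fluoro group can therefore be removed with no change in growth inhibition that stands out from the scatter at the concentration tested. Nothing in the data at hand accounts for this result.

The compounds shown leave open whether a different group on this carbon, such as methoxy, an amine or a carboxylic acid, would move the number beyond the scatter. They also leave open what a bromo group would do on the chain of compound 1, and what chain length does alone, as compound 2 and compound 3 each differ from compound 1 in more than one place.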